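Replacing the acid side chain of compound 2 with a cyclopropyl amide

The source may hold more compounds than are shown below. What is called first, only, known or untested is meant among the compounds shown, and "the series" means these compounds.

Measured compounds:
- compound 1, `Cc1nc(-c2ccc(C(F)(F)F)cc2)sc1CNc1ccc(CC(=O)O)cc1`: < 10000 nM
- compound 2, `Cc1nc(-c2ccc(C(F)(F)F)cc2)sc1CNc1ccc(C(C)CC(=O)O)cc1`: 58.9 nM
- compound 3, `CN(C)C(=O)CCc1ccc(NCc2cccc(Oc3ccccc3)c2)cc1`: 174 nM

All three compounds were tested in a functional assay on CHO cells for agonist activity at Free fatty acid receptor 1 (Homo sapiens); a lower number here means that less compound is needed, a higher number that more compound is needed for the effect. For compound 1 the result < 10000 nM is only a limit of the assay, not a number. Compound 2 gives 58.9 nM, the lowest of the two numbers shown. Compound 3, built on a different core, gives 174 nM, a gap to compound 2 that lies beyond the usual scatter.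

Going by the values given here, the one step between compounds that differ in a single place, a step that the limit leaves unreadable from compound 1 to compound 2, cannot be sized because of the limit of < 10000 nM in this assay, at which 1 of the 3 values shown sits. The step towards compound 4, `Cc1nc(-c2ccc(C(F)(F)F)cc2)sc1CNc1ccc([C@H]2C[C@@H]2C(=O)NC2CCNC2)cc1`, exchanges (2-((pyrrolidin-3-yl)carbamoyl)cyclopropyl in place of 1-(carboxymethyl)ethyl on an aromatic carbon). Among the compounds with values here, no measured step covers this kind of exchange, so there is no directly comparable size to lean on. With compound 2 as the only anchor, compound 4 is expected to give 300 nM, with a range from 60 nM to 3000 nM. This estimate corresponds to an expected step of a 5.1-fold higher number from compound 2 to compound 4 (0.71 log units; beyond the scatter), towards a higher number.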

Compound 4, half-maximal effective concentration: 204 nM
Compound 4: the middle estimate sits 1.5-fold (0.17 log units) above what was measured; the measured number falls inside the stated range.
By their numbers in this assay, from the lowest: compound 2; then compounds 3 and 4 (each within the scatter of the next).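

In this assay, placing 2-((pyrrolidin-3-yl)carbamoyl)cyclopropyl in place of 1-(carboxymethyl)ethyl raises the number only modestly: a 3.5-fold higher number from compound 2 to compound 4 (0.54 log units; beyond the scatter). On this core, the aromatic carbon para to a large group therefore accepts a larger group with no carboxylic acid and still gives a readable number, something compounds 1 and 2, which both carry a carboxylic acid, could not show. The step from compound 1 to compound 4 cannot be read, since compound 1 has only a limit and not a number: the limit of < 10000 nM in this assay, at which 1 of the 4 values shown sits.

On these data alone, this single exchange alters the chain, the acid and the ring content at once, so the share of each in the step stays open. As far as these compounds go, a 2-carboxycyclopropyl group or a cyclopentyl amide at this position would help separate them, and the other stereoisomers of the cyclopropane also remain open.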